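The source may hold more compounds than are shown below. What is called first, only, known or untested is meant among the compounds shown, and "the series" means these compounds.

Measured so far:
- compound 1, `COc1ccccc1N1CCN(CCCCC(=O)NCc2ccccc2-c2c(OC)cccc2OC)CC1`, in an assay on CHO-K1 cells for displacement of a labelled ligand from 5-hydroxytryptamine receptor 7 (Homo sapiens), read by scintillation counting (on this read-out higher numbers stand for weaker inhibition and lower numbers for stronger inhibition), gives 32.4 nM
- compound 2, `COc1ccccc1N1CCN(CCC(=O)NCc2ccccc2-c2ccccc2)CC1`, in this assay gives 187 nM

Compound 1 has the lowest number of the two. Among the compounds with values here, compound 2, its only neighbour, gives a higher number, a gap beyond the usual scatter, but the two differ in more than one place, so the two values alone say only that compound 1 sits lower.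

Compound 3, `COc1ccccc1N1CCN(CCCCC(=O)NCc2ccccc2-c2cccc(Cl)c2)CC1`, has not yet been measured. It differs from compound 1 in this way: 3-chlorophenyl in place of 2,6-dimethoxyphenyl on an aromatic carbon. Within the data shown here, no step between measured compounds shows what such a change does here, so the expectation rests on compound 1 alone. The step from compound 1 to compound 3 is expected to be a modest rise in number, a 2.0-fold higher number from compound 1 to compound 3 (0.30 log units; within the scatter), possibly within the scatter. Compound 3 is estimated at 65 nM, most likely between 20 nM and 220 nM.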

Compound 3, inhibition constant: 405 nM
The estimate for compound 3 lay 6.2-fold (0.79 log units) below the measured number; the whole stated range lies below it.
By their numbers in this assay, from the lowest: compound 1; then compound 2; then compound 3.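

At this aromatic carbon, ortho to a large group, the choice of aryl group counts for a lot: in this assay, 3-chlorophenyl in place of 2,6-dimethoxyphenyl gives a 13-fold higher number from compound 1 to compound 3 (1.10 log units; beyond the scatter). The rest of the molecule stays the same, so this single change is enough to weaken inhibition. Nothing available explains the size of this step.

As far as these compounds go, whether the step follows the loss of 2,6-dimethoxyphenyl or the arrival of 3-chlorophenyl stays open. Compounds carrying 2-methoxyphenyl or 2,6-dichlorophenyl at this place, on the same chain, could help separate the two.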